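Benzyl substituent change and cytotoxicity, outlook for compound 3

The compounds below may be only part of what the source reports. "The series", "measured", "known", "first", "only" and "open" are said of these compounds alone.

compound 1 `O=c1ccoc2cc(OCc3cn(Cc4ccccc4Cl)nn3)ccc12`: > 100000 nM
compound 2 `O=c1ccoc2cc(OCc3cn(Cc4ccccc4Br)nn3)ccc12`: 14500 nM

In a functional assay on HeLa cells (Homo sapiens) for cytotoxicity, read by MTT assay, with a stated time of 48 h (on this read-out lower numbers stand for stronger inhibition and higher numbers for weaker inhibition), compound 1 reaches only a limit, > 100000 nM. Within the data shown here, compound 2 gives 14500 nM in this assay, the one real number here. Among the measured compounds shown here, the single measured step, an at least 6.8-fold lower number from compound 1 to compound 2 (0.83 log units; beyond the scatter), reaches beyond the scatter, bounded by the limit of > 100000 nM in this assay, at which 1 of the 2 values shown sits. Compound 3 `N#Cc1cccc(Cn2cc(COc3ccc4c(=O)ccoc4c3)nn2)c1` differs from compound 2 by 3-cyanophenyl in place of 2-bromophenyl on a saturated chain carbon bound to an aromatic nitrogen. For the measured compounds named here, no measured step covers a halogen-to-nitrile exchange, so direction is open; the one step shows the benzyl substituent can move the read-out. Compound 3 is expected near 30000 nM, between 8000 nM and 100000 nM. The estimated step is a 2.1-fold higher number from compound 2 to compound 3 (0.32 log units; beyond the scatter), and a limit stays possible.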

Compound 3, half-maximal inhibitory concentration: > 100000 nM
Compound 3 ended at the assay's limit; the forecaster's own chance of this, stated with the estimate: 35%; at least 3.3-fold (0.52 log units) between middle value and limit.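

Replacing 2-bromobenzyl with 3-cyanobenzyl gives an at least 6.8-fold higher number from compound 2 to compound 3 (0.83 log units; beyond the scatter) in this assay. Compound 2 is therefore no longer alone in showing a change at this position that moves the read-out, but it remains the only one of the benzyl groups shown to give a real number: the limit of > 100000 nM in this assay, at which 2 of the 3 values shown sit. The step between compound 1 and compound 3 cannot be read, as both values are limits.

This change swaps the substituent and its ring position together, so the two effects remain unseparated. Going by these compounds, how 3-bromobenzyl, 2-cyanobenzyl or a benzyl group carrying an amine would read out remains open.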